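The source may hold more compounds than are shown below. What is called first, only, known or untested is meant among the compounds shown, and "the series" means these compounds.

Measured compounds:
- compound 3 `CCCCNc1nc(=O)c2cc(C(F)(F)F)cc([N+](=O)[O-])c2s1`: > 100000 nM
- compound 1 `CCCCNc1nc(=O)c2cc([N+](=O)[O-])cc([N+](=O)[O-])c2s1`: "not determined" (no result reported)
- compound 2 `CC(C)(C)OC(=O)N1CCN(c2nc(=O)c3cc([N+](=O)[O-])cc([N+](=O)[O-])c3s2)CC1`: "not determined" (no result reported)

In an ADME assay on Vero cells (Chlorocebus sabaeus) for cytotoxicity, read by MTT assay, with a stated time of 72 h (on this read-out higher numbers stand for weaker inhibition and lower numbers for stronger inhibition), compound 3 reports only a limit, > 100000 nM, which is a limit of the assay and not a number. Compound 1 carries no result in this assay, "not determined" (no result reported), and compound 2 likewise carries none, "not determined" (no result reported). Among the compounds with values here, of the three entries, one sits at the limit of > 100000 nM in this assay, at which 1 of the 3 values shown sits, and the other two give nothing to compare against, so no step between measured compounds is available.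

Compound 4 `O=c1nc(NC2CC2)sc2c([N+](=O)[O-])cc(C(F)(F)F)cc12` differs from compound 3 by cyclopropyl in place of butyl on a nitrogen on an aromatic ring. With compound 3 standing at a limit, no direction beyond the scatter is expected from this change in this assay; the step from compound 3 to compound 4 is estimated as a number no higher from compound 3 to compound 4 (the limit leaves the size open). Compound 4 is therefore expected to sit at 100000 nM, within 30000 nM to 300000 nM, most likely again reported only as a limit.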

Compound 4, half-maximal inhibitory concentration: > 100000 nM
Compound 4 was reported as a limit; the forecaster's own chance of this, stated with the estimate: 75%; the middle value lies on the limit itself.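

In this assay compound 3 and compound 4 each report only a limit, so no step can be read for butylamino to cyclopropylamino: the limit of > 100000 nM in this assay, at which 2 of the 4 values shown sit.
The compounds shown leave open whether any change on the shared core gives a single number in this assay.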